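Ring-opened oxygen substituent on the piperidine nitrogen side chain

This account rests on a few compounds, and the source may have more. Where it says the series, first, only, none or still open, it means among the compounds named here.

Three compounds sharing one core differ only in the group on a saturated chain carbon bound to an amine nitrogen in a ring. Compound 1 `COc1cccc(-n2cc3nc(-c4cccnc4C)n(C[C@H]4CCCN(CC5CCCCO5)C4)c(=O)c3n2)c1` carries oxan-2-yl there and gives 120 nM in an assay on HEK293 cells for displacement of a labelled ligand from growth hormone secretagogue receptor type 1 (Homo sapiens), with a stated time of 60 min; on this read-out higher numbers stand for weaker inhibition and lower numbers for stronger inhibition. Compound 2 `COc1cccc(-n2cc3nc(-c4cccnc4C)n(C[C@H]4CCCN(Cc5ccco5)C4)c(=O)c3n2)c1` carries furan-2-yl and gives 2.7 nM; compound 3 `COc1cccc(-n2cc3nc(-c4cccnc4C)n(C[C@H]4CCCN(CC5CCC5)C4)c(=O)c3n2)c1` carries cyclobutyl and gives 1.6 nM, the lowest of the three numbers, though its gap to compound 2 is within the scatter, shown by a 1.7-fold lower number from compound 2 to compound 3 (0.23 log units; within the scatter). The large steps are a 44-fold lower number from compound 1 to compound 2 (1.65 log units; beyond the scatter) and a 75-fold lower number from compound 1 to compound 3 (1.88 log units; beyond the scatter).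

Compound 4 `CCO[C@@H](C)CN1CCC[C@H](Cn2c(-c3cccnc3C)nc3cn(-c4cccc(OC)c4)nc3c2=O)C1` differs from compound 3 by 1-ethoxyethyl in place of cyclobutyl on a saturated chain carbon bound to an amine nitrogen in a ring. For the measured compounds named here, no measured pair tests exactly this change. The nearest guide is compound 1, which also carried a saturated group with one hydrogen-bond acceptor at this place and gave 120 nM, a much higher number than compound 3. Compound 4 is therefore expected to sit between these, with a 7.5-fold higher number from compound 3 to compound 4 (0.88 log units; beyond the scatter) as the expected step, giving an estimate of 12 nM and a likely range from 2.5 nM to 60 nM.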

Compound 4, half-maximal inhibitory concentration: 5 nM
For compound 4 the middle estimate is 2.4-fold (0.38 log units) above the measured one, and the stated range covers the measured number.
By their numbers in this assay, from the lowest: compounds 3, 2 and 4 (each within the scatter of the next, the first and the last beyond it); then compound 1.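

An oxygen in this side chain does not by itself bring the weak binding seen with oxan-2-yl: the open-chain 1-ethoxyethyl, which also has one hydrogen-bond acceptor, gives a 24-fold lower number from compound 1 to compound 4 (1.38 log units; beyond the scatter) in this assay. Against the all-carbon cyclobutyl, the same group gives only a 3.1-fold higher number from compound 3 to compound 4 (0.49 log units; beyond the scatter), while against furan-2-yl it gives a 1.9-fold higher number from compound 2 to compound 4 (0.27 log units; within the scatter), so those two cannot be told apart. Nothing measured here explains why the open chain and the oxan-2-yl ring differ so widely.

The compounds shown leave open how the opposite configuration at the stereocentre of 1-ethoxyethyl would read, and whether a plain all-carbon pentyl chain would match it. Also open, going by these compounds, is how an amine or a carboxylic acid would read at this place.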